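Cytotoxicity of Pyrazole Anilines: Bromo Versus Trifluoromethyl

The source may report more compounds than this note shows. Statements on the series, on what has been measured and on what is new or still open speak of the compounds shown alone.

Of the compounds shown here, three of one series have been measured in an ADME assay on Vero 76 cells (Chlorocebus sabaeus) for cytotoxicity, read by MTT assay, with a stated time of 96 h; a higher number here means that more compound is tolerated, a lower number that less compound is tolerated. Compound 1 `Cc1ccc(-c2nn(-c3ccccc3)cc2CNc2ccc(Br)cc2)cc1` gives 92000 nM in this assay. Compound 2 `Cc1ccc(-c2nn(-c3ccccc3)cc2CNc2ccc(C(F)(F)F)cc2)cc1` gives 45000 nM in this assay. Compound 3 `Brc1ccc(NCc2cn(-c3ccccc3)nc2-c2ccc(Br)cc2)cc1` gives 88000 nM in this assay.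

Compound 2 is made from compound 1 by one change, (trifluoromethyl in place of bromo on an aromatic carbon), and this change gave a 2.0-fold lower number from compound 1 to compound 2 (0.31 log units; beyond the scatter). Compound 3 is made from compound 1 by a different change, (bromo in place of methyl on an aromatic carbon), and this gave a 1.0-fold lower number from compound 1 to compound 3 (0.02 log units; within the scatter), so compound 1 and compound 3 cannot be told apart in this assay.

Compound 4 `FC(F)(F)c1ccc(-c2nn(-c3ccccc3)cc2CNc2ccc(Br)cc2)cc1` has not yet been measured. It differs from compound 3 by trifluoromethyl in place of bromo on an aromatic carbon, which is the same change that turns compound 1 into compound 2, made here on the core of compound 3 rather than the core of compound 1; the two cores differ by bromo in place of methyl on an aromatic carbon. Because the earlier step of a 2.0-fold lower number from compound 1 to compound 2 (0.31 log units; beyond the scatter) was modest and because compound 3 gives 88000 nM, the expected step is a 1.8-fold lower number from compound 3 to compound 4 (0.26 log units; within the scatter). The estimate for compound 4 in this assay is 48000 nM, with a range expected from 24000 nM to 96000 nM. This rests on a single earlier instance of the change, so the expectation is held loosely.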

Compound 4, half-maximal cytotoxic concentration: 17000 nM
Compound 4: the middle estimate sits 2.8-fold (0.45 log units) above what was measured, and the stated range ends above it.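

The change gave a 5.2-fold lower number from compound 3 to compound 4 (0.71 log units; beyond the scatter) in this assay, so on both cores trifluoromethyl in place of bromo goes with a lower tolerated concentration, and the new step cannot be told apart in size from the earlier one: the same change on two cores in this assay, a 2.0-fold lower number (0.31 log units; beyond the scatter) from compound 1 to compound 2 and a 5.2-fold lower number (0.71 log units; beyond the scatter) from compound 3 to compound 4, 2.5-fold (0.40 log units) apart, within the scatter of two such steps

The same trifluoromethyl group can also be set against methyl, and that change gave a 5.4-fold lower number from compound 1 to compound 4 (0.73 log units; beyond the scatter), which is a second step beyond the scatter and in the same direction. Even so, two pairs are a thin basis: they show that the direction held on both cores, but they do not show that the change has one fixed size, nor that the core has no influence on it, and they say nothing about why the number falls.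

What the compounds shown leave open is whether other groups in this place, such as a nitrile, an amine or a carboxylic acid, would lower the tolerated concentration as trifluoromethyl does or leave it where bromo and methyl stand. On these data alone, it also remains open whether the direction seen on these two cores would hold on a third core, or in cells other than the ones used here.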